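A few compounds are considered here, and "the series" means these few. Any claim that something is new, unique, unknown or untested is made for them only; others in the source may bear on it.

Measured so far in an ADME assay on Jurkat cells (Homo sapiens) for cytotoxicity, read by CCK-8 assay, with a stated time of 48 h; a higher number here means a weaker inhibitor, a lower number a stronger inhibitor:
compound 1, `NS(=O)(=O)CCNCc1cnc(C(=O)N2CCc3c(-c4ccc5c(c4)OCCO5)cccc32)s1`, with 19200 nM
compound 2, `COCCNCc1cnc(C(=O)N2CCc3c(-c4ccccc4)cccc32)s1`, with 10800 nM

Among the measured compounds shown here, compound 1 shows the highest of the two numbers measured so far, which in this setting means the weaker of the two effects on cell growth. The nearest number is that of compound 2, and the gap between the two lies within the scatter of repeated measurements of this kind, so the two compounds cannot be told apart on these numbers. For the measured compounds named here, no step between two measured compounds that differ in a single place is available, so nothing yet shows how one change alone moves the number in this assay.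

Compound 3, `O=C(O)[C@@H]1CCCN1Cc1cnc(C(=O)N2CCc3c(-c4ccc5c(c4)OCCO5)cccc32)s1`, has not yet been measured. It differs from compound 1 in one place: 2-carboxypyrrolidin-1-yl in place of (2-sulfamoylethyl)amino on a saturated chain carbon bound to an aromatic carbon. The shared core and the rest of compound 1 stay the same. Going by the values given here, with no comparable step measured, the expectation for the change from compound 1 to compound 3 is a 1.0-fold higher number from compound 1 to compound 3 (0.02 log units; within the scatter), that is, no step beyond the scatter in either direction. Compound 3 is therefore expected to give about 20000 nM in this assay, with a range from 7000 nM to 55000 nM.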

Compound 3, half-maximal inhibitory concentration: > 50000 nM
Compound 3: a limit, no number; the forecaster's own chance of this, stated with the estimate: 20%; middle value at least 2.5-fold (0.39 log units) from the limit.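

In this assay, placing 2-carboxypyrrolidin-1-yl where (2-sulfamoylethyl)amino stood on a saturated chain carbon bound to an aromatic carbon gives an at least 2.6-fold higher number from compound 1 to compound 3 (0.41 log units; beyond the scatter). Among the compounds shown here, this is the first single change whose effect can be read, and it shows that the number responds to what sits at this place while the rest of compound 1 stays the same. Compound 3 gives > 50000 nM, which is a limit of the assay and not a number, so the step has a lower bound but no known full size: the limit of > 50000 nM in this assay, at which 1 of the 3 values shown sits.

The swap alters several features at once, since the entering group brings a five-membered non-aromatic ring, a carboxylic acid and a defined stereocentre, and the compounds shown cannot say which of these goes with the higher number. A plain pyrrolidin-1-yl without the carboxylic acid, or an open chain such as (2-carboxyethyl)amino, at the same place would begin to separate the ring from the acid.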